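Ester capping of the phenol: from compound 1 to compound 3

This account rests on a few compounds, and the source may have more. Where it says the series, first, only, none or still open, it means among the compounds named here.

Measured so far:
compound 1 `COC(=O)/C(=C\c1ccc(O)cc1)Sc1ccnc2cc(Cl)ccc12`: 5180 nM
compound 2 `COC(=O)/C(=C\c1ccc(OC(=O)c2cc(OC)cc(OC)c2)cc1)Sc1ccnc2cc(Cl)ccc12`: 28900 nM

In a functional assay on Jurkat E6.1 cells (Homo sapiens) for cytotoxicity, read by MTT assay, with a stated time of 24 h (a lower number here means a stronger inhibitor, a higher number a weaker inhibitor), compound 1 gives the lowest of the two numbers; compound 2 gives the higher one. Compound 3 `COC(=O)/C(=C\c1ccc(OC(=O)c2c(OC)cccc2OC)cc1)Sc1ccnc2cc(Cl)ccc12` differs from compound 1 in one place: (2,6-dimethoxyphenyl)carbonyl in place of hydrogen on an oxygen on an aromatic ring. Among the measured compounds shown here, the only measured step that bears on this is a 5.6-fold higher number from compound 1 to compound 2 (0.75 log units; beyond the scatter), a related acyl group entering at the same oxygen. The step from compound 1 to compound 3 in this assay is therefore expected to be of similar direction and size, giving a modestly higher number. Compound 3 is expected to give about 20000 nM, within 7000 nM to 60000 nM, a step estimated as a 3.9-fold higher number from compound 1 to compound 3 (0.59 log units; beyond the scatter).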

Compound 3, half-maximal inhibitory concentration: 37500 nM
The estimate for compound 3 lay 1.9-fold (0.27 log units) below the measured number, and the stated range covers the measured number.
By their numbers in this assay, from the lowest: compound 1; then compounds 2 and 3 (each within the scatter of the next).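

In this assay a second acyl group at the same oxygen also moves the number up, with a 7.2-fold higher number from compound 1 to compound 3 (0.86 log units; beyond the scatter) beyond the scatter, so the rise seen with compound 2 is not confined to one acyl group. Replacing 3,5-dimethoxyphenyl with 2,6-dimethoxyphenyl on the carbonyl carbon gives a 1.3-fold higher number from compound 2 to compound 3 (0.11 log units; within the scatter) and so does not separate the two esters. No measurement shown accounts for the rise.

Still open, from the compounds shown here alone, is whether an acetyl group or an unsubstituted benzoyl at this oxygen would raise the number as well. A methyl ether there, or an acyl group carrying an amine, also remains untested among the compounds shown.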